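The source may report more compounds than this note shows. Statements on the series, on what has been measured and on what is new or still open speak of the compounds shown alone.

Values in a functional assay on BT-474 cells (Homo sapiens) for cytotoxicity, read by MTT assay, with a stated time of 48 h (a higher number here means a weaker inhibitor, a lower number a stronger inhibitor), read as half-maximal inhibitory concentrations:
compound 1, `COc1ccc(-c2nc(C(=O)/C=C\Nc3ccc4[nH]ccc4c3)c3ccccn23)cc1`: 13000 nM
compound 2, `COc1ccc(N/C=C\C(=O)c2nc(-c3ccc(F)cc3)n3ccccc23)cc1`: 15700 nM
compound 3, `COc1ccc(-c2nc(C(=O)/C=C\Nc3ccc(Cl)cc3)c3ccccn23)cc1`: 37300 nM

Compound 3 stands at the highest number of the three, with compound 2 nearest and compound 1 furthest, both gaps beyond the scatter. Compound 4, `COc1ccc(N/C=C\C(=O)c2nc(-c3ccc(OC)cc3)n3ccccc23)cc1`, is not yet measured. It differs from compound 3 by methoxy in place of chloro on an aromatic carbon, so that the (4-chlorophenyl)amino becomes a (4-methoxyphenyl)amino.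

Within the data shown here, one measured step touches the same anilino ring: a 2.9-fold higher number from compound 1 to compound 3 (0.46 log units; beyond the scatter), a modest rise on moving to the 4-chlorophenyl group. Among the measured compounds shown here, no measured step exchanges chloro for methoxy directly. Compound 2 already carries the (4-methoxyphenyl)amino group, though with a different aryl on the core, and its number is lower than that of compound 3; compound 1 and compound 3 show that the anilino substituent can shift this assay by a modest step. The expected step of a 2.1-fold lower number from compound 3 to compound 4 (0.32 log units; beyond the scatter) is therefore a modest drop, towards the values of compound 1 and compound 2, though it may fall inside the scatter.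

Compound 4 is estimated at 18000 nM, with a range from 9000 nM to 38000 nM.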

Compound 4, half-maximal inhibitory concentration: 15400 nM
Compound 4: middle estimate off by 1.2-fold (0.07 log units), on the high side, and the stated range covers the measured number.
By their numbers in this assay, from the lowest: compounds 1, 4 and 2 (each within the scatter of the next); then compound 3.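

In this assay, among these compounds, a 2.4-fold lower number from compound 3 to compound 4 (0.38 log units; beyond the scatter) is the first direct exchange of chloro for methoxy at this place, on an aromatic carbon para to a large group, and it is a modest step beyond the scatter. With the (4-methoxyphenyl)amino group held, methoxy in place of fluoro on the other aryl gives a 1.0-fold lower number from compound 2 to compound 4 (0.01 log units; within the scatter), and 4-methoxyphenyl in place of 1H-indol-5-yl on the amine nitrogen gives a 1.2-fold higher number from compound 1 to compound 4 (0.07 log units; within the scatter); both steps lie within the scatter, so among these four compounds, only compound 3, with its 4-chlorophenyl group, is set apart by steps beyond the scatter from compound 1 and compound 4. No measurement at hand accounts for these steps.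

As far as these compounds go, whether a dimethylamino group or a carboxylic acid at the same ring carbon would read with compound 4 or with compound 3 remains open. Also open, from the compounds shown here alone, is whether the step from chloro to methoxy keeps its size when the aryl on the shared core carries fluoro rather than methoxy.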